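One Isopropyl Fewer on a Shared Acid Core

The source may report more compounds than this note shows. Statements on the series, on what has been measured and on what is new or still open speak of the compounds shown alone.

compound 1 `CC(C)c1cc(C(C)C)c(C(=O)/C=C/C(=O)O)c(C(C)C)c1` — 8280 nM
compound 2 `COc1ccc(C(=O)/C=C/C(=O)O)c(OC)c1OC` — > 100000 nM
compound 3 `O=C(O)/C=C/C(=O)c1cc(C2CCCCC2)ccc1C1CCCCC1` — 4280 nM

In a functional assay on LS174T cells (Homo sapiens) for inhibition, read by MTT assay, with a stated time of 72 h (a higher number here means a weaker inhibitor, a lower number a stronger inhibitor), compound 1 gives 8280 nM, the higher of the two numbers measured, yet compound 3 at 4280 nM lies within the usual scatter of it, so no order between the two can be claimed. For compound 2 the value > 100000 nM is a limit of the assay and not a number (the limit of > 100000 nM in this assay, at which 1 of the 3 values shown sits). Compound 4 `CC(C)c1ccc(C(=O)/C=C/C(=O)O)c(C(C)C)c1` differs from compound 1 in a single place: hydrogen in place of isopropyl on an aromatic carbon. Going by the values given here, no measured pair shows this exact change, so the expected step rests on the few numbers above. Compound 4 is expected to give about 11000 nM, in the range 3500 nM to 35000 nM. The estimated step of a 1.3-fold higher number from compound 1 to compound 4 (0.12 log units; within the scatter) is expected to stay within the scatter or lean slightly toward a weaker inhibitor.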

Compound 4, half-maximal inhibitory concentration: 5360 nM
Compound 4: the middle estimate sits 2.1-fold (0.31 log units) above what was measured; the measured number falls inside the stated range.
By their numbers in this assay, from the lowest: compounds 3, 4 and 1 (each within the scatter of the next). At a limit, above all of these: compound 2.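

In this assay, hydrogen in place of isopropyl on the aromatic carbon ortho to the (2-carboxyethenyl)carbonyl group gives a 1.5-fold lower number from compound 1 to compound 4 (0.19 log units; within the scatter). Going by these compounds alone, this is the first pair here that differs in one place, and it shows that this isopropyl group can go without a difference that can be read beyond the scatter. No measurement shown bears on why this step is so small. Still open, on these data alone, is whether an amine or a longer chain on this carbon would shift the number beyond the scatter, and whether the two other isopropyl groups can also give way to hydrogen.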